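Quinolin-8-yl in place of methoxyphenyl on the sulfonyl

The source may report more compounds than this note shows. Statements on the series, on what has been measured and on what is new or still open speak of the compounds shown alone.

Measured compounds:
compound 1, `COc1cccc(S(=O)(=O)c2ccc(CN/C(=N\C#N)Nc3ccncc3)cc2)c1` — 55%
compound 2, `N#C/N=C(\NCc1ccc(S(=O)(=O)c2ccccc2)cc1)Nc1ccncc1` — 96%

In an ADME assay (liver) for metabolic stability, with Liver microsome (Homo sapiens) as the target, using microsomes, with a stated time of 30 min, tested at 1 uM (on this read-out lower numbers stand for a less stable compound and higher numbers for a more stable compound), compound 1 gives the lower of the two numbers, with compound 2 giving 96%. For the measured compounds named here, the one measured step, a number 41 percentage points higher from compound 1 to compound 2 (beyond the scatter), was large. Compound 3, `N#C/N=C(\NCc1ccc(S(=O)(=O)c2cccc3cccnc23)cc1)Nc1ccncc1`, carries the change (quinolin-8-yl in place of 3-methoxyphenyl on a sulfonyl sulfur). Going by the values given here, this change also removes the methoxy group, as did the step from compound 1 to compound 2, so a rise in this assay is expected, though the entering quinolin-8-yl has no measured counterpart, leaving the size uncertain. Compound 3 is therefore estimated at 72%, range 45% to 95%, a step of a number 17 percentage points higher from compound 1 to compound 3 (beyond the scatter) expected.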

Compound 3, percent of the compound remaining in the Liver microsome assay: 10%
For compound 3 the middle estimate is 62 percentage points above the measured one, outside the stated range (below it).
By their numbers in the Liver microsome assay, from the lowest: compound 3; then compound 1; then compound 2.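

In the Liver microsome assay the aromatic group on the sulfonyl sulfur moves the number down as well as up, with a number 45 percentage points lower from compound 1 to compound 3 (beyond the scatter) and a number 86 percentage points lower from compound 2 to compound 3 (beyond the scatter) when quinolin-8-yl enters, so losing the methoxy group does not by itself set the outcome. Compound 3 thus stands lowest of the three. The same change also lowers the number in a physicochemical assay for solubility, with a stated time of 24 h; on this read-out lower numbers stand for lower solubility and higher numbers for higher solubility: the measured solubility of compound 1, 51000 nM, and of compound 3, 18000 nM, a 2.8-fold lower number (0.45 log units; beyond the scatter). In the physicochemical assay compound 1 gives 51000 nM and compound 3 gives 18000 nM.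

The compounds shown leave open whether the drop follows the ring nitrogen of quinolin-8-yl or the larger aromatic group as a whole. Naphthyl or pyridinyl on the sulfonyl sulfur would separate the two.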